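From Dimethylcarbamoyl to Carboxyethyl: A Single Exchange

The source may hold more compounds than are shown below. What is called first, only, known or untested is meant among the compounds shown, and "the series" means these compounds.

Three amides built on a shared core have been measured in an assay on HeLa cells with Bile acid receptor (Homo sapiens) as the target, read by a luciferase reporter, with a stated time of 24 h; on this read-out higher numbers stand for an effect only at larger amounts of compound and lower numbers for an effect already at smaller amounts. Compound 1 `CN(C)C(=O)c1ccc(CNC(=O)c2ccc(C(C)(C)C)cc2)cc1` gives 170 nM, the highest of the three numbers. Compound 2 `CC(C)(C)c1ccc(C(=O)NCc2ccc(N)cc2Cl)cc1` gives 46 nM, and compound 3 `CC(NC(=O)c1ccc(C(C)(C)C)cc1)c1ccc(C(=O)O)cc1` gives 76 nM; both of these lie beyond the usual scatter from compound 1, compound 3 nearer to it and compound 2 farther away.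

Compound 4 `CC(C)(C)c1ccc(C(=O)NCc2ccc(CCC(=O)O)cc2)cc1` has not yet been measured in this assay. It differs from compound 1 in one place only: 2-carboxyethyl in place of dimethylcarbamoyl on an aromatic carbon. Going by the values given here, no pair of measured compounds shows this exact exchange, so the size of the step can only be expected, not read from the earlier measurements.

The expectation rests on compound 3, which also carries a carboxyl group and in this assay gives 76 nM, a lower number than compound 1. Accordingly a moderate step toward a lower number is expected, a 2.1-fold lower number from compound 1 to compound 4 (0.33 log units; beyond the scatter), not a large one. Compound 4 is therefore estimated to give 80 nM in this assay, with a plausible range from 25 nM to 250 nM.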

Compound 4, half-maximal effective concentration: 350 nM
Estimate against measurement, compound 4: 4.4-fold (0.64 log units) below; measured number above the stated range.
By their numbers in this assay, from the lowest: compounds 2 and 3 (each within the scatter of the next); then compound 1; then compound 4.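

At this aromatic carbon, para to a large group, putting 2-carboxyethyl in place of dimethylcarbamoyl gives in this assay a 2.1-fold higher number from compound 1 to compound 4 (0.31 log units; beyond the scatter), so the read-out responds to this exchange, if only modestly. The two groups have the same count of heavy atoms and neither contains a ring, but they differ in that 2-carboxyethyl has oxygen where dimethylcarbamoyl has nitrogen and brings a hydrogen-bond donor, so equal heavy-atom count alone does not fix the number at this position. Nothing shown here gives a measured reason for the step.

The compounds shown leave open whether the step follows the carboxylic acid itself or the chain that carries it, since the one exchange changes both at once. As far as these compounds go, a carboxylic acid set directly on the same aromatic carbon, a methyl ester of the 2-carboxyethyl group or an amine on a longer chain would help separate these two parts, and how any of them would read in this assay remains unknown.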